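Sulfonamide aryl swap at the assay ceiling

This account rests on a few compounds, and the source may have more. Where it says the series, first, only, none or still open, it means among the compounds named here.

Compound 1 `O=S(=O)(Nc1ccc(-c2nc3ccccc3o2)cc1)c1cccs1`: > 63000 nM, a limit of the assay
Compound 2 `O=S(=O)(Nc1ccc2oc(-c3ccccc3)nc2c1)c1ccc(Cl)c(C(F)(F)F)c1`: > 63000 nM, a limit of the assay
Compound 3 `Cc1cccc(S(=O)(=O)Nc2ccc3oc(-c4ccccc4)nc3c2)c1`: > 63000 nM, a limit of the assay

All three were tested in an assay on isolated protein for inhibition of malate dehydrogenase, mitochondrial (Sus scrofa), with stated times of 45 min and 30 min; a lower number here means a stronger inhibitor, a higher number a weaker inhibitor. In this assay compound 1 gives > 63000 nM, which is a limit of the measurement and not a number. Compound 2 likewise gives > 63000 nM as a limit. Compound 3 gives > 63000 nM, again a limit. Compound 1 therefore stands where every value shown stands, since (the limit of > 63000 nM in this assay, at which 3 of the 3 values shown sit). Going by the values given here, no step between two measured compounds with a number on both sides is available, so nothing can be said about the size of any change within the shared core of compound 1.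

Compound 4 `Cc1ccc(S(=O)(=O)Nc2ccc(-c3nc4ccccc4o3)cc2)cc1` differs from compound 1 in one place: 4-methylphenyl in place of thiophen-2-yl on a sulfonyl sulfur. Among the compounds with values here, because of the limit of > 63000 nM in this assay, at which 3 of the 3 values shown sit, there is no measured step to carry over. The expectation for compound 4 is that the change a step that the limit leaves unreadable from compound 1 to compound 4 brings no movement beyond the usual scatter, and that the assay again reports only a limit. Compound 4 is estimated at 100000 nM, with a range from 40000 nM to 300000 nM.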

Compound 4, half-maximal inhibitory concentration: > 63000 nM
Compound 4 gave a limit, no number; the forecaster's own chance of this, stated with the estimate: 85%; the middle value lies beyond the limit too.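

Placing 4-methylphenyl in place of thiophen-2-yl on a sulfonyl sulfur gives no readable step between compound 1 and compound 4, because neither returns a number in this assay: the limit of > 63000 nM in this assay, at which 4 of the 4 values shown sit. The compounds shown leave open how far each lies from that limit, and whether any change to the shared core would bring a measurable value.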